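Para substituent swap on the trifluoroethoxy lactam series

A few compounds are considered here, and "the series" means these few. Any claim that something is new, unique, unknown or untested is made for them only; others in the source may bear on it.

Measured so far:
compound 1 `O=C1C=CC(OCC(F)(F)F)N1c1ccc(C(F)(F)F)cc1` — 36200 nM
compound 2 `O=C1C=CC(OCC(F)(F)F)N1c1ccc([N+](=O)[O-])cc1` — 2380 nM

In a functional assay on HeLa cells (Homo sapiens) for inhibition (a higher number here means a weaker inhibitor, a lower number a stronger inhibitor), compound 2 gives 2380 nM, the lowest of the two numbers in hand; the nearest is compound 1, and the step of a 15-fold lower number from compound 1 to compound 2 (1.18 log units; beyond the scatter) is large and beyond the scatter. Compound 3 `O=C1C=CC(OCC(F)(F)F)N1c1ccc(Br)cc1` is not yet measured. It differs from compound 2 by bromo in place of nitro on an aromatic carbon, the change sitting on an aromatic carbon of the six-membered carbon-only ring, para to a large group.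

Among the compounds with values here, no measured step bears directly on bromo at this position. Within the data shown here, the only step available, a 15-fold lower number from compound 1 to compound 2 (1.18 log units; beyond the scatter), shows that the nitro compound 2 sits well apart from the trifluoromethyl compound 1, so the nitro group is tied to the lower number. Removing it for bromo is expected to move the number back up, probably not to the full extent of compound 1, but the direction is uncertain with one pair only. The expected step is a 4.2-fold higher number from compound 2 to compound 3 (0.62 log units; beyond the scatter). For compound 3 the estimate in this assay is 10000 nM, with a range from 2500 nM to 40000 nM.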

Compound 3, half-maximal inhibitory concentration: 7060 nM
Estimate against measurement, compound 3: 1.4-fold (0.15 log units) above, and the stated range covers the measured number.
By their numbers in this assay, from the lowest: compound 2; then compound 3; then compound 1.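

In this assay, the position now carries three groups on the shared core, and bromo takes the middle place: a 3.0-fold higher number from compound 2 to compound 3 (0.47 log units; beyond the scatter), while a 5.1-fold lower number from compound 1 to compound 3 (0.71 log units; beyond the scatter), both modest but beyond the scatter. The series therefore gives a graded order at this aromatic carbon, with nitro lowest, bromo next and trifluoromethyl highest, rather than nitro standing apart from the other two groups. Replacing nitro with a single bromine atom removes its 2 hydrogen-bond acceptors without returning the number to that of compound 1, so in this set those acceptors are not needed for a number below that of compound 1, and no measurement at hand explains the order of the three groups.

The compounds shown leave open how an amine, a carboxylic acid, a nitrile or a smaller halogen such as chloro would rank against these three groups at the same position. As far as these compounds go, all three compounds also carry the same trifluoroethoxy group, so it remains open whether the order would hold with a methoxy or a longer chain in its place.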